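The compounds below may be only part of what the source reports. "The series", "measured", "known", "first", "only" and "open" are said of these compounds alone.

Measured so far in a functional assay on HT-29 cells (Homo sapiens) for antiproliferative activity, read by sulforhodamine B assay, with a stated time of 48 h; on this read-out higher numbers stand for weaker inhibition and lower numbers for stronger inhibition:
compound 1, `COc1ccc(NS(=O)(=O)c2ccc(N3CCNC3=O)cc2)cc1`, 800 nM
compound 2, `O=C1NCCN1c1ccc(S(=O)(=O)Nc2ccc(Br)cc2)cc1`, 300 nM
compound 3, `Cc1cc(C)cc(NS(=O)(=O)c2ccc(N3CCNC3=O)cc2)c1`, 82 nM

Compound 1 gives the highest of the three numbers in this assay; the nearest step is a 2.7-fold lower number from compound 1 to compound 2 (0.43 log units; beyond the scatter), the furthest a 9.8-fold lower number from compound 1 to compound 3 (0.99 log units; beyond the scatter).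

Compound 4 `O=C1NCCN1c1ccc(S(=O)(=O)Nc2cccc(Cl)c2)cc1` differs from compound 1 in one place: 3-chlorophenyl in place of 4-methoxyphenyl on a sulfonamide nitrogen. Among the compounds with values here, two measured steps bear on this change. The first is a 2.7-fold lower number from compound 1 to compound 2 (0.43 log units; beyond the scatter), the second 9.8-fold lower number from compound 1 to compound 3 (0.99 log units; beyond the scatter); both go in the same direction, and both are modest. A modest step to a lower number in this assay is therefore expected for compound 4, closer in size to the smaller of the two. Compound 4 is estimated at 300 nM, with a range from 120 nM to 750 nM, which means an expected 2.7-fold lower number from compound 1 to compound 4 (0.43 log units; beyond the scatter).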

Compound 4, half-maximal inhibitory concentration: 55 nM
Beside the measured number, compound 4's estimate is 5.5-fold (0.74 log units) above it; measured number below the stated range.
By their numbers in this assay, from the lowest: compounds 4 and 3 (each within the scatter of the next); then compound 2; then compound 1.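

On the sulfonamide nitrogen, 3-chlorophenyl gives the largest step yet in this assay (a 15-fold lower number from compound 1 to compound 4 (1.16 log units; beyond the scatter)), and it also clearly outdoes 4-bromophenyl (a 5.5-fold lower number from compound 2 to compound 4 (0.74 log units; beyond the scatter)). Against 3,5-dimethylphenyl it shows no separation (a 1.5-fold lower number from compound 3 to compound 4 (0.17 log units; within the scatter)), so these two groups stand level, while 4-methoxyphenyl and 4-bromophenyl both give higher numbers. Nothing available explains these differences.

The compounds shown do not separate the place of the halogen from its identity, since a 4-chlorophenyl group is absent from them. They also leave open how a ring carrying an amine or a carboxylic acid would fare on this nitrogen.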